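Plasma half-life of a diester series: a third member

The compounds below may be only part of what the source reports. "The series", "measured", "known", "first", "only" and "open" are said of these compounds alone.

Two members of this series have been measured in an ADME assay on a cell-free system (plasma, Homo sapiens) for metabolic stability, with Plasma (Rattus norvegicus) as the target, read by HPLC, at pH 7.4; a higher number here means that the compound lasts longer, a lower number that the compound disappears faster. Compound 1 `CC(=O)Oc1ccccc1C(=O)O[C@H]1CO[C@H]2[C@@H]1OC[C@H]2OC(=O)C1CC1` gives 0.0322 h. Compound 2 `CC(=O)Oc1ccccc1C(=O)O[C@H]1CO[C@H]2[C@@H]1OC[C@H]2OC(=O)c1ccc(C#N)cc1` carries a 4-cyanophenyl on the carbonyl carbon where compound 1 carries a cyclopropyl. In this assay, for the measured compounds named here, compound 2 gives 0.0888 h and so holds the higher of the two numbers; the only known step is a 2.8-fold higher number from compound 1 to compound 2 (0.44 log units; beyond the scatter). Compound 3 `CC(=O)Oc1ccccc1C(=O)O[C@H]1CO[C@H]2[C@@H]1OC[C@H]2OC(=O)c1cccc(CO[N+](=O)[O-])c1` differs from compound 2 in one place: 3-((nitrooxy)methyl)phenyl in place of 4-cyanophenyl on a carbonyl carbon. Going by the values given here, no measured step exchanges one aromatic group for another, so the step from compound 1 to compound 2 bears on this change only loosely: it shows that altering the group on this carbonyl carbon can move this assay by a modest amount. For compound 3 the expected step is a 1.3-fold lower number from compound 2 to compound 3 (0.10 log units; within the scatter), likely within the scatter, with the lower side judged a little more probable. Compound 3 is therefore estimated at 0.07 h, in the range 0.03 h to 0.16 h.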

Compound 3, half-life: 0.0433 h
Estimate against measurement, compound 3: 1.6-fold (0.21 log units) above; the range from low to high includes it.
By their numbers in this assay, from the lowest: compounds 1 and 3 (each within the scatter of the next); then compound 2.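

In this assay, for the compounds shown here, exchanging one aromatic group for another on this carbonyl carbon is not neutral: 3-((nitrooxy)methyl)phenyl in place of 4-cyanophenyl gives a 2.1-fold lower number from compound 2 to compound 3 (0.31 log units; beyond the scatter), the first measured step between two aromatic groups at this place. Set against cyclopropyl, the same group gives a 1.3-fold higher number from compound 1 to compound 3 (0.13 log units; within the scatter), so the rise seen with 4-cyanophenyl does not extend to both aromatic groups shown. No measured information accounts for the difference between these two aromatic groups.

These compounds do not tell whether the nitrooxy part of the new group or its place on the phenyl ring sets the step. Also open, as far as these compounds go, is how an unsubstituted phenyl, an amine or a longer alkyl chain on this carbonyl carbon would read in this assay.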